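From Methyl to (4-Chlorophenyl)sulfonyl in Compound 1

A few compounds are considered here, and "the series" means these few. Any claim that something is new, unique, unknown or untested is made for them only; others in the source may bear on it.

In a functional assay on QGY-7703 cells (Homo sapiens) for cytotoxicity, read by MTT assay, with a stated time of 24 h (a higher number here means a weaker inhibitor, a lower number a stronger inhibitor), compound 1 (`CN1C/C(=C\c2cccnc2)C(=O)/C(=C/c2ccccc2F)C1`) gives 4470 nM and compound 2 (`CN1C/C(=C\c2ccncc2)C(=O)/C(=C/c2ccccc2F)C1`) gives 4900 nM. Within the data shown here, the two cannot be told apart, with a 1.1-fold higher number from compound 1 to compound 2 (0.04 log units; within the scatter), so compound 1 stands level with its only measured neighbour. Compound 3 (`O=C1/C(=C/c2cccnc2)CN(S(=O)(=O)c2ccc(Cl)cc2)C/C1=C\c1ccccc1F`) carries (4-chlorophenyl)sulfonyl in place of methyl on an amine nitrogen in a ring. Among the measured compounds shown here, no measured step touches that nitrogen. The only one available, a 1.1-fold higher number from compound 1 to compound 2 (0.04 log units; within the scatter), concerns the pyridine group instead, and it gives no size or direction for this change. The best guess therefore stays close to compound 1 at 4470 nM, with wide uncertainty and no firm direction. The expected change is a 1.3-fold lower number from compound 1 to compound 3 (0.11 log units; within the scatter), which is only an estimate. In this assay, compound 3 is estimated at 3500 nM, with an expected range of 900 nM to 13000 nM.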

Compound 3, half-maximal inhibitory concentration: 12100 nM
Compound 3: middle estimate off by 3.5-fold (0.54 log units), on the low side, and the stated range covers the measured number.
By their numbers in this assay, from the lowest: compounds 1 and 2 (each within the scatter of the next); then compound 3.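

In this assay, the amine nitrogen in the ring is a place where a change registers: a 2.7-fold higher number from compound 1 to compound 3 (0.43 log units; beyond the scatter), a modest step but one beyond the scatter, whereas the swap between the pyridine groups stayed within it. The direction is also now known, with (4-chlorophenyl)sulfonyl giving a weaker inhibitor than methyl, though one that still has a measurable value in this assay. No measurement at hand accounts for the rise.

Still open, from the compounds shown here alone, is whether the rise belongs to the sulfonyl link or to the 4-chlorophenyl part, which a compound bearing phenylsulfonyl, benzyl or acetyl on this nitrogen would help to separate. Going by these compounds, it is also open whether the same change on the pyridin-4-yl compound, compound 2, would give a step of similar size.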